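The source may report more compounds than this note shows. Statements on the series, on what has been measured and on what is new or still open speak of the compounds shown alone.

Compound 1 `Nc1ccccc1NC(=O)c1ccc(CSC(=S)N2CCCc3ccccc32)cc1` and compound 2 `CN(Cc1ccncc1)C(=S)SCc1ccc(C(=O)Nc2ccccc2N)cc1` share one core and differ only at the thiocarbonyl carbon. In a functional assay on HeLa cells (Homo sapiens) for antiproliferative activity, read by CCK-8 assay, with a stated time of 72 h, tested at 2 uM (on this read-out higher numbers stand for a stronger effect at the one concentration tested and lower numbers for a weaker effect), compound 2 gives 29.5% and compound 1 gives 26.1%, two numbers that lie within the scatter of each other. Among the measured compounds shown here, the one measured step, a number 3.4 percentage points higher from compound 1 to compound 2 (within the scatter), put methyl((pyridin-4-yl)methyl)amino in place of 1,2,3,4-tetrahydroquinolin-1-yl on a thiocarbonyl carbon. Compound 3 `Nc1ccccc1NC(=O)c1ccc(CSC(=S)N2CCCC2)cc1` changes that same place again: pyrrolidin-1-yl in place of methyl((pyridin-4-yl)methyl)amino on a thiocarbonyl carbon. Because the earlier change at this place, a number 3.4 percentage points higher from compound 1 to compound 2 (within the scatter), stayed within the scatter, no shift beyond the scatter is expected here. Compound 3 is therefore estimated at 26%, between 12% and 40%. That estimate means an expected step of a number 3.5 percentage points lower from compound 2 to compound 3 (within the scatter).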

Compound 3, a percentage reported as inhibition, at one concentration (the size of the read-out at that concentration, not a potency): 51.3%
Compound 3: the middle estimate sits 25.3 percentage points below what was measured; measured number outside the range, above it.
By their numbers in this assay, from the lowest: compounds 1 and 2 (each within the scatter of the next); then compound 3.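

In this assay the group on this thiocarbonyl carbon does matter: pyrrolidin-1-yl brings a number 21.8 percentage points higher from compound 2 to compound 3 (beyond the scatter) and also a number 25.2 percentage points higher from compound 1 to compound 3 (beyond the scatter) and both steps lie beyond the scatter. Among the three groups shown, only this five-membered non-aromatic ring stands apart from the other two. No measurement shown gives a reason for this gain.

As far as these compounds go, whether the gain is specific to pyrrolidin-1-yl remains open. Piperidin-1-yl, morpholin-4-yl or a simple dimethylamino group on the same carbon would show whether it extends to other amines.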